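Fluoro to bromo on the phenyl ring of compound 3

The source may hold more compounds than are shown below. What is called first, only, known or untested is meant among the compounds shown, and "the series" means these compounds.

Three measured compounds share one core and differ only in a single group on a phenyl ring. Compound 1 `c1ccc(-c2cn3ccnc3c(-c3ccc4ncn(C5CCCCC5)c4c3)n2)cc1` gives 59.8% in a functional assay on SR cells (Homo sapiens) for inhibition, read by sulforhodamine B assay, with a stated time of 48 h, tested at 10 uM; on this read-out lower numbers stand for less inhibition and higher numbers for more inhibition at the one concentration tested (going by the name of the read-out). Compound 2 `COc1ccc(-c2cn3ccnc3c(-c3ccc4ncn(C5CCCCC5)c4c3)n2)cc1` gives 91.7% in this assay, while compound 3 `Fc1ccc(-c2cn3ccnc3c(-c3ccc4ncn(C5CCCCC5)c4c3)n2)cc1` gives 20.4%, the lowest of the three numbers. Compound 4 `Brc1ccc(-c2cn3ccnc3c(-c3ccc4ncn(C5CCCCC5)c4c3)n2)cc1` differs from compound 3 by bromo in place of fluoro on an aromatic carbon. Going by the values given here, no measured pair makes exactly this exchange, but every change at this place was large: a number 31.9 percentage points higher from compound 1 to compound 2 (beyond the scatter), a number 39.4 percentage points lower from compound 1 to compound 3 (beyond the scatter) and a number 71.3 percentage points lower from compound 2 to compound 3 (beyond the scatter). A new group here can therefore move the number far, in either direction, so a large step is expected with real uncertainty about its sign. Compound 4 is expected to rise by a number 24.6 percentage points higher from compound 3 to compound 4 (beyond the scatter), giving an estimated 45%, with a likely range from 15% to 80%.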

Compound 4, a percentage reported as inhibition, at one concentration (the size of the read-out at that concentration, not a potency): 60.7%
Estimate against measurement, compound 4: 15.7 percentage points below, within the range that was stated.
By their numbers in this assay, from the lowest: compound 3; then compounds 1 and 4 (each within the scatter of the next); then compound 2.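

The two halogens at this place do not give the same result: bromo in place of fluoro raises the number (a number 40.3 percentage points higher from compound 3 to compound 4 (beyond the scatter)), so the low number of compound 3 is not shared by compound 4. Bromo in place of methoxy lowers it (a number 31 percentage points lower from compound 2 to compound 4 (beyond the scatter)), while bromo in place of hydrogen leaves no readable difference (a number 0.9 percentage points higher from compound 1 to compound 4 (within the scatter)). Nothing available here explains these differences. The compounds shown leave open where chloro would fall relative to fluoro and bromo. They also leave open whether an amine or a longer ether such as ethoxy would match methoxy.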